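A few compounds are considered here, and "the series" means these few. Any claim that something is new, unique, unknown or untested is made for them only; others in the source may bear on it.

Measured compounds:
- compound 1 `O=S(=O)(c1ccc(F)c(F)c1)c1cnc2c(F)cccc2c1-c1cccc(Cl)c1`: 1.13 mL/min
- compound 2 `N#Cc1cccc(S(=O)(=O)c2cnc3c(F)cccc3c2-c2cccc(Cl)c2)c1`: 1.11 mL/min

In an ADME assay on microsomes from liver (Homo sapiens) for metabolic stability, tested at 2.5 uM (a higher number here means faster removal of the compound, a lower number slower removal), compound 1 gives 1.13 mL/min. In this assay compound 2 gives 1.11 mL/min. Compound 2 stands alongside compound 1: a 1.0-fold lower number from compound 1 to compound 2 (0.01 log units; within the scatter), so the pair is indistinguishable on this read-out.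

Compound 3 `N#Cc1cccc(S(=O)(=O)c2cnc3c(F)cccc3c2-c2ccccc2F)c1` is not yet measured. It differs from compound 2 in this way: 2-fluorophenyl in place of 3-chlorophenyl on an aromatic carbon. Within the data shown here, the one measured step, a 1.0-fold lower number from compound 1 to compound 2 (0.01 log units; within the scatter), changes the group on the sulfonyl sulfur and leaves the group at this position untouched, so no measured step bears directly on the change from compound 2 to compound 3. Both measured numbers sit close together, and the shared core of compound 2 is kept. The expectation for compound 3 is therefore no step beyond the scatter in this assay, that is a 1.0-fold lower number from compound 2 to compound 3 (0.00 log units; within the scatter). Compound 3 is estimated at 1.1 mL/min, with a range from 0.55 mL/min to 2.2 mL/min.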

Compound 3, intrinsic clearance in a liver preparation (reported as CLH), per the amount of preparation that the assay uses: 0.66 mL/min
Compound 3: the middle estimate sits 1.7-fold (0.22 log units) above what was measured; the range from low to high includes it.
By their numbers in this assay, from the lowest: compounds 3, 2 and 1 (each within the scatter of the next).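

Among these compounds, this is the first reading at the aromatic carbon opposite the ring nitrogen: in this assay, 2-fluorophenyl in place of 3-chlorophenyl gives a 1.7-fold lower number from compound 2 to compound 3 (0.23 log units; within the scatter), so changing both the halogen and its place on this phenyl ring does not separate the two compounds on this read-out. Alongside a 1.0-fold lower number from compound 1 to compound 2 (0.01 log units; within the scatter), a change on the sulfonyl sulfur, each of the two places has now been varied once, and neither step lies beyond the scatter. No measurement among the data speaks to what lies behind the size of this step.

From the compounds shown here alone, it remains open whether a group of another kind at this position, such as a morpholine or a carboxylic acid, would give a step beyond the scatter. Also open, going by these compounds, is whether 2-fluorophenyl gives a similar reading with 3,4-difluorophenyl on the sulfonyl sulfur.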